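The source may report more compounds than this note shows. Statements on the series, on what has been measured and on what is new or still open speak of the compounds shown alone.

Within the data shown here, in an ADME assay on GES1 cells (Homo sapiens) for inhibition, read by MTT assay, with a stated time of 72 h (on this read-out higher numbers stand for weaker inhibition and lower numbers for stronger inhibition), only two compounds have been measured so far. Compound 1 `CCCCCc1c(C)nc2nc(SCc3ccc(Cl)cc3)nn2c1Nc1cc(-c2ccccc2)[nH]n1` reached a limit of the assay, > 50000 nM, and so gave no actual number. Among the measured compounds shown here, compound 2 `Cc1cc(Nc2ccn(Cc3ccc(F)cc3)n2)n2nc(SCc3ccc(Br)cc3)nc2n1` gave 40500 nM, the only actual number available, which leaves it with weak inhibition and no measured neighbour for comparison. Compound 3 `Cc1cc(Nc2ccn(Cc3nc(C)c4ccccc4n3)n2)n2nc(SCc3ccc(Br)cc3)nc2n1` keeps the rest of compound 2 but carries 4-methylquinazolin-2-yl in place of 4-fluorophenyl on a saturated chain carbon bound to an aromatic nitrogen. For the measured compounds named here, no measured pair shows what such a change does in this assay. With compound 2 at 40500 nM, only a small shift towards stronger inhibition is expected, hardly beyond the scatter. The estimate is a step of a 1.4-fold lower number from compound 2 to compound 3 (0.13 log units; within the scatter). For compound 3 the expected value is 30000 nM, with an estimated range of 10000 nM to 70000 nM.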

Compound 3, half-maximal inhibitory concentration: 36800 nM
The estimate for compound 3 lay 1.2-fold (0.09 log units) below the measured number; the range from low to high includes it.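

In this assay, the piece now has its first readable step at this position, on a saturated chain carbon bound to an aromatic nitrogen: 4-methylquinazolin-2-yl in place of 4-fluorophenyl gives a 1.1-fold lower number from compound 2 to compound 3 (0.04 log units; within the scatter). A group of 11 heavy atoms with 2 hydrogen-bond acceptors thus reads the same as one of 7 heavy atoms with none, so neither the larger group nor its acceptors show any effect on this read-out. Any weaker reading at this position would have little room before the assay's limit, a limit and not a number, reached by compound 1: the limit of > 50000 nM in this assay, at which 1 of the 3 values shown sits.

As far as these compounds go, whether an amine or a carboxylic acid on the same chain carbon would move the number beyond the scatter remains open. So does whether any group at this position can give clearly stronger inhibition.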